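The source may hold more compounds than are shown below. What is called first, only, known or untested is meant among the compounds shown, and "the series" means these compounds.

Measured so far in a functional assay on MIA PaCa-2 cells (Homo sapiens) for inhibition, read by MTT assay, with a stated time of 3 days; a lower number here means a stronger inhibitor, a higher number a weaker inhibitor:
compound 1 `O=C([C@@H]1CCCN(S(=O)(=O)c2ccc(S(=O)(=O)N3CC[C@@H](O)C3)cc2)C1)N1CCC(F)(F)CC1` gives > 3000 nM, which is a limit of the assay and not a number.
compound 2 `CCN(CC)S(=O)(=O)c1ccc(S(=O)(=O)N2CCC[C@@H](C(=O)N3CCC(C(F)(F)F)CC3)C2)cc1` gives > 10000 nM, again a limit.
compound 3 `CN(C)S(=O)(=O)c1ccc(S(=O)(=O)N2CCC[C@@H](C(=O)N3CCC(F)(F)CC3)C2)cc1` gives > 3000 nM, again a limit.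

Compound 2 thus stands at the limit of > 10000 nM in this assay, at which 1 of the 3 values shown sits, while the other two values sit at the limit of > 3000 nM in this assay, at which 2 of the 3 values shown sit; none of the three is a measured number. Compound 4 `CCN(CC)S(=O)(=O)c1ccc(S(=O)(=O)N2CCC[C@@H](C(=O)N3CCC(C(F)F)CC3)C2)cc1` differs from compound 2 by hydrogen in place of fluoro on a saturated chain carbon bound to two fluorine atoms and a saturated ring carbon. Within the data shown here, no measured step covers this change: the only single-point step, a step that the two limits leave unreadable from compound 1 to compound 3, sits elsewhere in the molecule and cannot be read. Starting from a limit with no readable guidance, compound 4 is expected to give 10000 nM in this assay, in the range 3000 nM to 30000 nM. That expectation means a step of a number no higher from compound 2 to compound 4 (the limit leaves the size open), most likely reported once more only as a limit.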

Compound 4, half-maximal inhibitory concentration: > 10000 nM
Compound 4 was reported as a limit; the forecaster's own chance of this, stated with the estimate: 75%; the middle value sits exactly at the limit.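

Compound 2 and compound 4 are both reported only as limits, so the step from trifluoromethyl to difluoromethyl cannot be read. The compounds shown leave open how strongly any of them acts in this assay: none has a measured number.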